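The source may hold more compounds than are shown below. What is called first, only, known or untested is meant among the compounds shown, and "the series" means these compounds.

Series notes, alkoxy variation on the shared core. In an assay on cells with melanin-concentrating hormone receptor 1 (Homo sapiens) as the target, read by radioligand binding (on this read-out higher numbers stand for weaker inhibition and lower numbers for stronger inhibition), compound 1 `CCC(C)COc1cccc2ccc(N)nc12` gives 36 nM, the strongest of the three measured; compound 3 `CCCCCOc1cccc2ccc(N)nc12` gives 580 nM and compound 2 `CC1CC1COc1cccc2ccc(N)nc12` gives 1640 nM. Both measured steps start from compound 1: a 16-fold higher number from compound 1 to compound 3 (1.21 log units; beyond the scatter) and a 46-fold higher number from compound 1 to compound 2 (1.66 log units; beyond the scatter); between the other two, a 2.8-fold lower number from compound 2 to compound 3 (0.45 log units; beyond the scatter). Compound 4 `CC(C)OCCOc1cccc2ccc(N)nc12` is the next step from compound 1: isopropoxymethyl in place of sec-butyl on a saturated chain carbon bound to an oxygen on an aromatic ring. Each change tried so far on this saturated chain carbon weakened inhibition by a large margin, so a large rise in the number in this assay is expected for compound 4 as well, a 17-fold higher number from compound 1 to compound 4 (1.22 log units; beyond the scatter). The estimate for compound 4 is 600 nM, with a range of 150 nM to 2500 nM.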

Compound 4, half-maximal inhibitory concentration: > 2000 nM
Compound 4: a limit, no number (the forecaster's own chance of this, stated with the estimate: 5%); at least 3.3-fold (0.52 log units) between middle value and limit.
By their numbers in this assay, from the lowest: compound 1; then compound 3; then compound 2. At a limit, above all of these: compound 4.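

Compound 4 carries a limit of the assay, not a number: the limit of > 2000 nM in this assay, at which 1 of the 4 values shown sits. Even as a floor the step is large: an at least 55-fold higher number from compound 1 to compound 4 (1.74 log units; beyond the scatter). Among these compounds, this is the first change at this saturated chain carbon that brings in a hydrogen-bond acceptor. The same change also falls behind the butyl chain, an at least 3.4-fold higher number from compound 3 to compound 4 (0.53 log units; beyond the scatter). The remaining step settles little, an at least 1.2-fold higher number from compound 2 to compound 4 (0.08 log units; that floor lies within the scatter).

Going by these compounds, the true value of compound 4 stays open. So does whether the loss follows the chain oxygen itself, which a terminal amine or hydroxyl on a longer chain could test.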